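The compounds below may be only part of what the source reports. "The series", "measured", "known", "first", "only" and "open" are said of these compounds alone.

Measured compounds so far:
Compound 1, `CCCSc1nc(N/N=C/c2ccccc2F)c2nnn(Cc3ccccc3)c2n1`: in a functional assay on MCF7 cells (Homo sapiens) for antiproliferative activity, read by MTT assay, with a stated time of 72 h (on this read-out higher numbers stand for weaker inhibition and lower numbers for stronger inhibition), compound 1 gives > 64000 nM, which is a limit of the assay and not a number.
Compound 2, `CCCSc1nc(N/N=C(\C)c2ccccc2O)c2nnn(Cc3ccco3)c2n1`: in this assay compound 2 gives 29000 nM.
Compound 3, `CCCSc1nc(N/N=C/c2cccc(Cl)c2)c2nnn(Cc3ccccc3)c2n1`: in this assay compound 3 gives > 64000 nM, again a limit of the assay rather than a number.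

Compound 1 therefore stands at the limit, and it shares that position with one other compound, as the limit of > 64000 nM in this assay, at which 2 of the 3 values shown sit, shows. For the measured compounds named here, the only measured step that changes a single place, a step that the two limits leave unreadable from compound 1 to compound 3, cannot be read, since both of its ends are limits. Compound 4, `CCCSc1nc(N/N=C/c2c(O)ccc3ccccc23)c2nnn(Cc3ccccc3)c2n1`, differs from compound 1 in one place: 2-hydroxynaphthalen-1-yl in place of 2-fluorophenyl on a carbon with a double bond to nitrogen. Going by the values given here, no measured step bears directly on this change. Among the compounds with values here, compound 2, which also carries a hydroxyl on its ring, is the one compound that gives a number, but it differs from compound 1 in several places at once, so only its value can be noted. On this thin basis, compound 4 is expected to stay weak, with a fair chance of a limit. Compound 4 is estimated at 35000 nM, within a range from 12000 nM to 64000 nM. The expected step is an at least 1.8-fold lower number from compound 1 to compound 4 (0.26 log units; that floor lies within the scatter).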

Compound 4, half-maximal inhibitory concentration: 6400 nM
For compound 4 the middle estimate is 5.5-fold (0.74 log units) above the measured one; measured number below the stated range.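

For the compounds shown here, on the carbon with a double bond to nitrogen, the earlier compounds offered only a step that cannot be read, whereas in this assay 2-hydroxynaphthalen-1-yl in place of 2-fluorophenyl gives an at least 10-fold lower number from compound 1 to compound 4 (1.00 log units; beyond the scatter), and in place of 3-chlorophenyl it gives an at least 10-fold lower number from compound 3 to compound 4 (1.00 log units; beyond the scatter). This position can therefore move the read-out beyond the usual scatter while the rest of the molecule stays the same. Both steps are floors and not exact sizes, since their starting compounds sit at a limit of the assay and not at a number: the limit of > 64000 nM in this assay, at which 2 of the 4 values shown sit.

The hydroxyl and the second aromatic ring enter together, so the compounds shown leave open which of them carries the change. A plain naphthalen-1-yl, or a naphthalene carrying an amine in place of the hydroxyl, would help to separate the two.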